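A few compounds are considered here, and "the series" means these few. Any claim that something is new, unique, unknown or untested is made for them only; others in the source may bear on it.

The compounds here share one core, and what changes is the group attached to an amide. Compound 1 `CCOC(=O)C1CCN(C(=O)CN2CN(c3ccccc3)C3(CCN(C(=O)c4ccc(C5CCCCC5)cc4)CC3)C2=O)CC1` carries an ethoxycarbonyl on a saturated ring carbon, and in an assay on HEK293 cells for displacement of a labelled ligand from NPC1-like intracellular cholesterol transporter 1 (Homo sapiens) (on this read-out lower numbers stand for stronger inhibition and higher numbers for weaker inhibition), compound 1 gives 900 nM. Compound 3 `O=C(CN1CN(c2ccccc2)C2(CCN(C(=O)c3ccc(C4CCCCC4)cc3)CC2)C1=O)N1CCC(CO)CC1` carries a hydroxymethyl on that saturated ring carbon instead, and in this assay compound 3 gives 1100 nM. The step of a 1.2-fold higher number from compound 1 to compound 3 (0.09 log units; within the scatter) is small. Compound 2 `CC(C)(C)OC(=O)NCCNC(=O)CN1CN(c2ccccc2)C2(CCN(C(=O)c3ccc(C(C)(C)C)cc3)CC2)C1=O` differs in its benzoyl substituent as well as in its amide group, and in this assay compound 2 gives 10900 nM. Among the three measured numbers compound 3 stands second highest, within the scatter of compound 1 and well apart from compound 2.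

Compound 4 `CC(C)(C)OC(=O)NCCNC(=O)CN1CN(c2ccccc2)C2(CCN(C(=O)c3ccc(C4CCCCC4)cc3)CC2)C1=O` is not yet measured. It differs from compound 3 in one place: (2-((tert-butoxycarbonyl)amino)ethyl)amino in place of 4-(hydroxymethyl)piperidin-1-yl on a carbonyl carbon. Among the compounds with values here, no measured step covers this exact exchange. The step from compound 1 to compound 3 swaps one small group for another and stays within the scatter, so it says little about replacing the whole ring. Compound 2, which carries the same entering group, shows a far higher number than compound 3, though its benzoyl substituent also differs. On that basis the number for compound 4 is expected to rise by about a 4.5-fold higher number from compound 3 to compound 4 (0.66 log units; beyond the scatter), giving an estimate of 5000 nM with a range from 1500 nM to 15000 nM.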

Compound 4, half-maximal inhibitory concentration: 5500 nM
Compound 4: the middle estimate sits 1.1-fold (0.04 log units) below what was measured; the measured number falls inside the stated range.
By their numbers in this assay, from the lowest: compounds 1 and 3 (each within the scatter of the next); then compounds 4 and 2 (each within the scatter of the next).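

Putting the open-chain (2-((tert-butoxycarbonyl)amino)ethyl)amino on the carbonyl carbon in place of 4-(hydroxymethyl)piperidin-1-yl gives a 5.0-fold higher number from compound 3 to compound 4 (0.70 log units; beyond the scatter), and replacing 4-(ethoxycarbonyl)piperidin-1-yl in the same way gives a 6.1-fold higher number from compound 1 to compound 4 (0.79 log units; beyond the scatter), so in this assay the number responds to exchanging the whole group at this position, which the small change on the ring, a 1.2-fold higher number from compound 1 to compound 3 (0.09 log units; within the scatter), did not show. With this chain in place, cyclohexyl in place of tert-butyl on an aromatic carbon gives a 2.0-fold lower number from compound 2 to compound 4 (0.30 log units; within the scatter), a step within the scatter, so this exchange shows no clear effect on the number here. Nothing available explains why the number changes at the carbonyl position.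

The exchange removes the ring and adds the chain with its tert-butoxycarbonyl end in a single step, so these compounds do not separate the contribution of each part. A free primary amine at the end of the ethyl chain, or an unsubstituted piperidin-1-yl on the carbonyl carbon, would help to tell those parts apart.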